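The compounds below may be only part of what the source reports. "The series", "measured", "known", "first", "only" and "open" are said of these compounds alone.

Compounds measured in an assay on liver for binding affinity to Alpha-1A adrenergic receptor (Homo sapiens), using microsomes; a lower number here means a stronger inhibitor, a higher number a weaker inhibitor:
compound 1 `COC(=O)C1=C(C)NC(=O)N(C(=O)NCCCN2CCN(c3ccc(OC)cc3C)CC2)C1c1ccc(F)c(F)c1`: 16 nM
compound 2 `COC(=O)C1=C(C)NC(=O)N(C(=O)NCCCN2CCN(c3ccccc3Cl)CC2)C1c1ccc(F)c(F)c1`: 0.2 nM
compound 3 `COC(=O)C1=C(C)NC(=O)N(C(=O)NCCCN2CCN(c3cccc(Cl)c3)CC2)C1c1ccc(F)c(F)c1`: 0.7 nM

Compound 1 stands highest of the three numbers; the nearest to it is compound 3 at 0.7 nM, the furthest compound 2 at 0.2 nM.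

Compound 4 `COC(=O)C1=C(C)NC(=O)N(C(=O)NCCCN2CCN(c3cccc([N+](=O)[O-])c3)CC2)C1c1ccc(F)c(F)c1` differs from compound 1 in one place: 3-nitrophenyl in place of 4-methoxy-2-methylphenyl on an amine nitrogen in a ring

For the measured compounds named here, two measured steps bear directly on this change, both starting from compound 1 and both replacing the 4-methoxy-2-methylphenyl with a chlorophenyl: an 80-fold lower number from compound 1 to compound 2 (1.90 log units; beyond the scatter) and a 23-fold lower number from compound 1 to compound 3 (1.36 log units; beyond the scatter). Both are large and both run toward lower numbers. Between the two chlorophenyls the step is modest, a 3.5-fold higher number from compound 2 to compound 3 (0.54 log units; beyond the scatter), so the exact position of a single group on the phenyl matters less than the replacement of the 4-methoxy-2-methylphenyl itself. The nearer comparison for compound 4 is compound 3, since 3-chlorophenyl and 3-nitrophenyl share their naming. No nitro group has been measured in this series, so whether it tracks chloro fully is open. A large step toward a lower number is expected, tempered for the untested group: compound 4 is estimated at 2 nM, in the range 0.4 nM to 10 nM, which means an expected step of an 8.0-fold lower number from compound 1 to compound 4 (0.90 log units; beyond the scatter).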

Compound 4, inhibition constant: 12 nM
Compound 4: the middle estimate sits 6.0-fold (0.78 log units) below what was measured; the measured number lies above the stated range.
By their numbers in this assay, from the lowest: compound 2; then compound 3; then compounds 4 and 1 (each within the scatter of the next).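

In this assay, leaving the 4-methoxy-2-methylphenyl is not enough on its own to reach the low numbers of the chlorophenyl compounds: the change to 3-nitrophenyl gives a 1.3-fold lower number from compound 1 to compound 4 (0.12 log units; within the scatter). The group carried on the phenyl therefore matters at this position, since nitro in place of chloro gives a 17-fold higher number from compound 3 to compound 4 (1.23 log units; beyond the scatter), and the change from 2-chlorophenyl to 3-nitrophenyl gives a 60-fold higher number from compound 2 to compound 4 (1.78 log units; beyond the scatter); among the replacements shown, the low numbers belong to compounds 2 and 3, and compound 4 goes against any reading that credits the replacement alone. No supporting data bear on why nitro and chloro part so widely here.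

Going by these compounds, it remains open whether an unsubstituted phenyl, or a phenyl carrying fluoro, methoxy or a nitrile, would sit with compounds 2 and 3 or with compound 4. Also open, on these data alone, is how a 2-nitrophenyl would compare with the 2-chlorophenyl of compound 2, and how a 2-methylphenyl and a 4-methoxyphenyl would each compare with the 4-methoxy-2-methylphenyl of compound 1.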